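The source may hold more compounds than are shown below. What is called first, only, known or untested is meant among the compounds shown, and "the series" means these compounds.

Among the compounds with values here, compound 3 `O=C(CCC1=CCN(Cc2ccccc2)C1=O)NO` gives 5370 nM in a functional assay on HCT-15 cells (Homo sapiens) for antiproliferative activity (on this read-out higher numbers stand for weaker inhibition of growth and lower numbers for stronger inhibition of growth), the highest of the three numbers so far. Compound 1 `COc1cccc(CN2CC=C(CCC(=O)NO)C2=O)c1` gives 2820 nM and compound 2 `O=C(CCC1=CCN(Cc2cccc(C(F)(F)F)c2)C1=O)NO` gives 540 nM. The step of a 9.9-fold higher number from compound 2 to compound 3 (1.00 log units; beyond the scatter) lies beyond the scatter, whereas a 1.9-fold higher number from compound 1 to compound 3 (0.28 log units; within the scatter) does not. Compound 4 `COc1ccccc1CN1CC=C(CCC(=O)NO)C1=O` brings (methoxy in place of hydrogen on an aromatic carbon). Within the data shown here, the one measured step that bears on this is the same exchange in reverse between compound 1 and compound 3, where a 1.9-fold higher number from compound 1 to compound 3 (0.28 log units; within the scatter) stayed within the scatter; in compound 4 the methoxy sits ortho to a large group, so the bearing is loose. For compound 4 no step beyond the scatter is expected, a 1.5-fold lower number from compound 3 to compound 4 (0.19 log units; within the scatter). Compound 4 is therefore estimated at 3500 nM, with a range of 1400 nM to 8500 nM.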

Compound 4, concentration for 50% growth inhibition: > 10000 nM
Compound 4 was reported as a limit (the forecaster's own chance of this, stated with the estimate: 5%); at least 2.8-fold (0.45 log units) between middle value and limit.
By their numbers in this assay, from the lowest: compound 2; then compounds 1 and 3 (each within the scatter of the next). At a limit, above all of these: compound 4.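

In this assay, compound 4 is reported as a limit and not a number: the limit of > 10000 nM in this assay, at which 1 of the 4 values shown sits. The step, an at least 1.8-fold higher number from compound 3 to compound 4 (0.27 log units; that floor lies within the scatter), therefore gives only a floor, and its true size cannot be read. Among the compounds shown, only methoxy ortho to a large group reaches the limit, while compound 1 also carries methoxy and has a measured number.

As far as these compounds go, whether fluoro or an amine on that same aromatic carbon also reaches the limit remains open. So does the effect of a longer chain between the core and the benzyl ring.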